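Swapping a phenylethyl arm for a short aminoethyl chain

The source may report more compounds than this note shows. Statements on the series, on what has been measured and on what is new or still open speak of the compounds shown alone.

This set of compounds shares one core, shown in compound 1 `C[C@@H](Nc1c(C(=O)NCc2ccc(F)cc2)nc(Br)c2cccnc12)c1ccccc1`. Each carries an amide arm and a side chain on a nitrogen on an aromatic ring, and the side chain is where the compounds differ. Compound 1 has no result in a functional assay on MCF7 cells (Homo sapiens) for cytotoxicity, read by MTT assay, with a stated time of 72 h; on this read-out lower numbers stand for stronger inhibition and higher numbers for weaker inhibition; its entry reads "not determined" (no result reported). Compound 2 `N[C@H]1CC[C@H](Nc2c(C(=O)NCc3ccc(Oc4ccccc4)cc3)nc(Br)c3cccnc23)CC1`, which carries a diaminocyclohexyl chain, gives 7900 nM in this assay. Compound 3 `N[C@H]1CC[C@H](Nc2c(C(=O)NCc3ccc(Cl)cc3Cl)nc(Br)c3cccnc23)CC1`, with the same chain and a dichlorinated amide arm, also has no reported result; its entry reads "not determined" (no result reported).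

Compound 4 `NCCNc1c(C(=O)NCc2ccc(F)cc2)nc(Br)c2cccnc12` is the untested member. It differs from compound 1 by 2-aminoethyl in place of 1-phenylethyl on a nitrogen on an aromatic ring. Going by the values given here, since compound 1 has no number, no measured step can anchor the direction of this change; the only number in the set, that of compound 2, belongs to a compound that carries an amine on its chain much as compound 4 does. Compound 4 is therefore expected to sit near that figure, with an estimate of 9000 nM in this assay and a likely range from 2500 nM to 35000 nM.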

Compound 4, half-maximal inhibitory concentration: 6000 nM
For compound 4 the middle estimate is 1.5-fold (0.18 log units) above the measured one; the range from low to high includes it.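

Going by these compounds alone, compound 4 gives no new step: in this assay compound 1 has no single number to set against it. Nothing shown here offers an explanation for the value of compound 4. Going by these compounds, the effect of exchanging 1-phenylethyl for 2-aminoethyl on cytotoxicity remains open.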